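The compounds below may be only part of what the source reports. "The series", "measured", "known", "first", "only" and "open" are said of these compounds alone.

Measured compounds:
compound 1 `O=S(=O)(Nc1ccc(-c2nc3cc(NS(=O)(=O)c4ccccc4Cl)ccc3o2)cc1)c1ccccc1Cl`, 17000 nM;
compound 2 `COc1ccc(S(=O)(=O)Nc2ccc3oc(-c4ccc(NS(=O)(=O)c5cc(F)ccc5OC)cc4)nc3c2)cc1`, 18000 nM;
compound 3 `COc1ccc(S(=O)(=O)Nc2ccc3oc(-c4ccc(NS(=O)(=O)c5cc(Br)ccc5OC)cc4)nc3c2)cc1`, 15000 nM.

In a functional assay on DLD-1 cells (Homo sapiens) for cytotoxicity, read by resazurin assay, with a stated time of 48 h (a higher number here means that more compound is needed for the effect, a lower number that less compound is needed), compound 1 gives 17000 nM, compound 2 gives 18000 nM and compound 3 gives 15000 nM. Going by the values given here, compound 3 has the lowest of the three numbers, but its neighbours lie close: compound 1 sits within the scatter of it, and the only single-point step, a 1.2-fold lower number from compound 2 to compound 3 (0.08 log units; within the scatter), is also within the scatter. The three sulfonamides are therefore not separated by this assay.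

Compound 4 `COc1ccc(S(=O)(=O)Nc2ccc3oc(-c4ccc(NC(=O)C5CCN(C(C)=O)CC5)cc4)nc3c2)cc1` differs from compound 3 at one place: (1-acetylpiperidin-4-yl)carbonyl in place of (5-bromo-2-methoxyphenyl)sulfonyl on a nitrogen on an aromatic ring. Among the compounds with values here, none of the measured steps bears on this change. The step of a 1.2-fold lower number from compound 2 to compound 3 (0.08 log units; within the scatter) exchanges one halogen for another on an aromatic carbon, whereas here a whole arylsulfonyl group is traded for a non-aromatic carbonyl-linked ring, so it gives no guide to size or direction. With the three measured numbers all crowded near the same value, the expectation for compound 4 in this assay rests on that crowd alone: the step of a 1.3-fold higher number from compound 3 to compound 4 (0.12 log units; within the scatter) is estimated to be small, with a wide range to allow for the untested change. Compound 4 is thus expected to give about 20000 nM, between 5000 nM and 80000 nM.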

Compound 4, half-maximal effective concentration: 15000 nM
Beside the measured number, compound 4's estimate is 1.3-fold (0.12 log units) above it, and the stated range covers the measured number.
By their numbers in this assay, from the lowest: compounds 3, 4, 1 and 2 (each within the scatter of the next).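

The earlier compounds shown here showed only one halogen exchanged for another, whereas compound 4 replaces the whole (5-bromo-2-methoxyphenyl)sulfonyl group on a nitrogen on an aromatic ring with (1-acetylpiperidin-4-yl)carbonyl. In this assay, this much larger change gives no change at the digits printed from compound 3 to compound 4 (within the scatter), and the comparison with the fluoro compound gives a 1.2-fold lower number from compound 2 to compound 4 (0.08 log units; within the scatter), so among these compounds neither the sulfonyl link nor the six-membered aromatic ring of carbon only is needed on this nitrogen for a number of this size. Nothing available accounts for why such different groups give numbers within the scatter of each other.

All four compounds lie within the scatter of one another in this assay, so the compounds shown leave open whether any group on this nitrogen can move the number beyond the scatter, in either direction. From the compounds shown here alone, whether an amine or a carboxylic acid in place of the acetyl group, or a longer chain in place of the piperidine ring, would do so also remains open.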